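Losing the imidazolylmethyl group from a trimethoxybenzamide

This account rests on a few compounds, and the source may have more. Where it says the series, first, only, none or still open, it means among the compounds named here.

Measured compounds:
- compound 1 `CCOC(=O)c1sc2ccc(NCc3nc[nH]c3C)cc2c1NC(=O)c1ccc(C)cc1`: 11400 nM
- compound 2 `CCOC(=O)c1sc2ccc(NCc3nc[nH]c3C)cc2c1NC(=O)c1cc(OC)c(OC)c(OC)c1`: 2230 nM
- compound 3 `CCOC(=O)c1sc2ccc(N)cc2c1NC(=O)c1ccc(C)cc1`: 24400 nM

The three compounds were tested in a functional assay on HeLa cells (Homo sapiens) for antiproliferative activity, read by MTT assay, with a stated time of 48 h; a higher number here means a weaker inhibitor of growth, a lower number a stronger inhibitor of growth. Within this set compound 2 gives the lowest number, with compound 1 next and compound 3 furthest away; both gaps are beyond the scatter.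

Compound 2 differs from compound 1 in one place: 3,4,5-trimethoxyphenyl in place of 4-methylphenyl on a carbonyl carbon. This change gave a 5.1-fold lower number from compound 1 to compound 2 (0.71 log units; beyond the scatter). The other change in the set is hydrogen in place of (5-methyl-1H-imidazol-4-yl)methyl on a nitrogen on an aromatic ring, and it gave a 2.1-fold higher number from compound 1 to compound 3 (0.33 log units; beyond the scatter).

The unmeasured compound 4 `CCOC(=O)c1sc2ccc(N)cc2c1NC(=O)c1cc(OC)c(OC)c(OC)c1` stands to compound 2 as compound 3 stands to compound 1: hydrogen in place of (5-methyl-1H-imidazol-4-yl)methyl on a nitrogen on an aromatic ring. The place of the change is described in the same words for both pairs, so this is the same change, now made on the core that carries the trimethoxyphenyl group rather than the methylphenyl group. The only guide to its effect is the step from compound 1 to compound 3, and whether that step carries over onto the other core is not shown by any measured pair here.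

On that basis compound 4 is expected to give a 2.1-fold higher number from compound 2 to compound 4 (0.32 log units; beyond the scatter), because the same change gave a 2.1-fold higher number from compound 1 to compound 3 (0.33 log units; beyond the scatter). The estimated value for compound 4 is therefore 4700 nM, with the expectation falling between 2400 nM and 9500 nM.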

Compound 4, concentration for 50% growth inhibition: 4660 nM
Beside the measured number, compound 4's estimate is 1.0-fold (0.00 log units) above it; the measured number falls inside the stated range.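

In this assay, hydrogen in place of (5-methyl-1H-imidazol-4-yl)methyl on the nitrogen gave a 2.1-fold higher number from compound 2 to compound 4 (0.32 log units; beyond the scatter). For the compounds shown here, this step matches the one seen on the core bearing the 4-methylphenyl group, so within this pair of cores the change carried over with no difference beyond the scatter: the same change on two cores in this assay, a 2.1-fold higher number (0.33 log units; beyond the scatter) from compound 1 to compound 3 and a 2.1-fold higher number (0.32 log units; beyond the scatter) from compound 2 to compound 4, 1.0-fold (0.01 log units) apart, within the scatter of two such steps The agreement rests on only two cores, which differ solely in the group on the carbonyl carbon, so it does not show that the step would hold on a core changed anywhere else, and it does not explain why the number rises when the group is lost.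

The nitrogen carries only hydrogen or (5-methyl-1H-imidazol-4-yl)methyl in these compounds, which leaves open how a benzyl group, an acetyl group or an unsubstituted imidazolylmethyl group there would compare on either core. As far as these compounds go, the compounds also all keep the ethyl ester, so it remains open whether the same step would appear with a carboxylic acid or a primary amide in its place, or with a benzamide bearing a different group, such as a 4-methoxyphenyl group, on the carbonyl carbon.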